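The source may report more compounds than this note shows. Statements on the series, on what has been measured and on what is new or still open speak of the compounds shown alone.

Compound 1 `O=C(O)Cn1nnc(-c2cc(OCCOCc3cc(F)ccc3Br)no2)n1` gives 305 nM in an assay on microsomes from liver for inhibition of acyl-CoA desaturase 1 (Rattus norvegicus); on this read-out lower numbers stand for stronger inhibition and higher numbers for weaker inhibition.
Compound 2 `O=C(O)Cn1nnc(-c2nnc(OCCCOc3cc(F)ccc3Br)s2)n1` gives 26 nM in this assay.
Compound 3 `O=C(O)Cn1nnc(-c2cnc(OCCCOc3cc(F)ccc3Br)s2)n1` gives 5 nM in this assay.

Among these three, compound 3 shows the lowest number. The nearest value is that of compound 2, which lies a good deal higher, and the value of compound 1 stands further off still; both gaps are beyond the usual scatter, so compound 3 is the strongest inhibitor of the three in this assay. Among the measured compounds shown here, compound 2 and compound 1 each differ from compound 3 in more than one place, so no single structural step between any of these pairs can be drawn out from their values alone.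

Compound 4 `O=C(O)Cn1nnc(-c2cnc(OCCCOc3cc(OC(F)(F)F)ccc3Br)s2)n1` has not yet been measured. It differs from compound 3 by one change only: trifluoromethoxy in place of fluoro on an aromatic carbon. The group sits on an aromatic carbon of a six-membered aromatic ring of carbon only, meta to a large group and para to a bromo group. No comparable exchange of groups on that ring appears among the measured compounds, so the direction of the step rests on the expectation that the altered substituent is tolerated much as the fluoro group was. The step from compound 3 to compound 4 is therefore expected to be small, a 1.6-fold higher number from compound 3 to compound 4 (0.20 log units; within the scatter), and may well fall within the scatter. Compound 4 is estimated at 8 nM, with a range from 2 nM to 30 nM.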

Compound 4, half-maximal inhibitory concentration: 2 nM
The estimate for compound 4 lay 4.0-fold (0.60 log units) above the measured number; the measured number falls inside the stated range.
By their numbers in this assay, from the lowest: compound 4; then compound 3; then compound 2; then compound 1.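

In this assay, among the compounds shown here, trifluoromethoxy in place of fluoro gives a 2.5-fold lower number from compound 3 to compound 4 (0.40 log units; beyond the scatter) and so provides the first step between compounds that differ in one place, a modest one that lies beyond the usual scatter. The earlier compounds shown here said nothing about this aromatic carbon, meta to a large group and para to a bromo group, whereas this pair shows that a substituent of 5 heavy atoms can stand there instead of one of 1 heavy atom without any loss of inhibition, and with a somewhat lower number. No measurement offered here explains this gain, so the step stands as an observation only.

With a single exchange at this position, the compounds shown cannot tell whether the lower number goes with the added size, the added oxygen or the fluorines, and a methoxy group, a trifluoromethyl group or a nitrile on the same carbon would begin to separate these. Going by these compounds, it also remains open whether the same exchange would bring a similar step on the cores of compound 1 and compound 2, which differ from compound 3 in more than one place.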